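Chloro for Methyl in a Nicotinic Receptor Binding Series

This account rests on a few compounds, and the source may have more. Where it says the series, first, only, none or still open, it means among the compounds named here.

Of the compounds shown here, three have so far been measured in an assay on membranes from brain for displacement of a labelled ligand from Neuronal acetylcholine receptor; alpha4/beta2 (Rattus norvegicus); on this read-out lower numbers stand for stronger inhibition and higher numbers for weaker inhibition. Compound 1 `CN1CCC[C@H]1COc1cncc(Cl)c1` gives 0.6 nM. Compound 2 `Cc1cncc(OC[C@@H]2CCCN2C)c1` gives 0.48 nM in this assay. Compound 3 `Cc1ccc(OC[C@@H]2CCCN2C)cn1` gives 1.26 nM in this assay, the highest number of the three and beyond the scatter from both others. Compound 1 differs from compound 2 by chloro in place of methyl on an aromatic carbon, and this step was a 1.3-fold higher number from compound 2 to compound 1 (0.10 log units; within the scatter). The difference between the cores of compound 2 and compound 3 is not broken down here.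

Compound 4 `CN1CCC[C@H]1COc1ccc(Cl)nc1` has not yet been measured. It differs from compound 3 by chloro in place of methyl on an aromatic carbon. This is the same kind of change as that from compound 2 to compound 1, but the place differs: in compound 4 the chloro sits next to the ring nitrogen and para to a group of 8 heavy atoms, whereas in compound 1 it sits two atoms from the ring nitrogen and meta to such a group. A step of similar small size is expected, a 1.2-fold higher number from compound 3 to compound 4 (0.08 log units; within the scatter), because the same kind of change gave a 1.3-fold higher number from compound 2 to compound 1 (0.10 log units; within the scatter). Compound 4 is therefore expected to give 1.5 nM in this assay, most likely between 0.6 nM and 4 nM.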

Compound 4, inhibition constant: 0.64 nM
Beside the measured number, compound 4's estimate is 2.3-fold (0.37 log units) above it, within the range that was stated.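

In this assay, chloro in place of methyl on an aromatic carbon gave a 2.0-fold lower number from compound 3 to compound 4 (0.29 log units; within the scatter). Set beside the earlier case, the two steps cannot be told apart: the same change on two cores in this assay, a 1.3-fold higher number (0.10 log units; within the scatter) from compound 2 to compound 1 and a 2.0-fold lower number (0.29 log units; within the scatter) from compound 3 to compound 4, 2.5-fold (0.39 log units) apart, within the scatter of two such steps. Among the compounds shown here, this shows that in these two pairs the change could be carried from one core to the other with no step beyond the scatter, but it rests on only two pairs, gives no measurable effect of core or of where the chloro sits, and says nothing about how the change would read on any other core.

From the compounds shown here alone, only methyl and chloro are compared here, so it remains open how bromo, methoxy or a nitrile would read in this assay on either core. Going by these compounds, it is equally open whether an amine or a longer chain in that place would give a step beyond the scatter, and whether such a step would carry from one core to the other.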